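Swapping the para group on a diphenylcarbinol piperidine

A few compounds are considered here, and "the series" means these few. Any claim that something is new, unique, unknown or untested is made for them only; others in the source may bear on it.

Measured so far:
Compound 1 `O=C(CCCN1CCC(C(O)(c2ccccc2)c2ccccc2)CC1)c1ccc(Br)cc1`: 4200 nM
Compound 2 `COc1ccc(C(=O)CCCN2CCC(C(O)(c3ccccc3)c3ccccc3)CC2)cc1`: 7600 nM

These two compounds were tested in an in vitro assay on Sf9 cells for inhibition of cytochrome P450 2J2 (Homo sapiens); a higher number here means a weaker inhibitor, a lower number a stronger inhibitor. Compound 1 gives 4200 nM and compound 2 gives 7600 nM in this assay. Among the measured compounds shown here, compound 2 has the higher of the two numbers, but the only step so far, a 1.8-fold higher number from compound 1 to compound 2 (0.26 log units; within the scatter), is within the scatter, so the two compounds cannot be ordered against each other on these data.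

Compound 3 `O=C(CCCN1CCC(C(O)(c2ccccc2)c2ccccc2)CC1)c1ccc(CC(F)F)cc1` is not yet measured. It differs from compound 2 in one place: 2,2-difluoroethyl in place of methoxy on an aromatic carbon. For the measured compounds named here, no measured step involves a 2,2-difluoroethyl group, so the single known step, which exchanged bromo for methoxy at the same place and stayed within the scatter, is the only guide. On that basis no change beyond the scatter is expected in this assay, and the estimated step of a 1.5-fold lower number from compound 2 to compound 3 (0.18 log units; within the scatter) is correspondingly small. Compound 3 is therefore expected to give about 5000 nM in this assay, with a plausible range from 1500 nM to 16000 nM.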

Compound 3, half-maximal inhibitory concentration: 2200 nM
The estimate for compound 3 lay 2.3-fold (0.36 log units) above the measured number; the range from low to high includes it.
By their numbers in this assay, from the lowest: compounds 3, 1 and 2 (each within the scatter of the next, the first and the last beyond it).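

In this assay, the place on the aromatic ring para to a large group now shows a change beyond the scatter: 2,2-difluoroethyl in place of methoxy gives a 3.5-fold lower number from compound 2 to compound 3 (0.54 log units; beyond the scatter), a modest step. The same group in place of bromo gives a 1.9-fold lower number from compound 1 to compound 3 (0.28 log units; within the scatter), so compound 1 and compound 3 cannot be ordered, and only the methoxy and 2,2-difluoroethyl compounds are separated at this place. Nothing available here explains why the number moves with this change.

The swap from methoxy to 2,2-difluoroethyl changes several things at once: the group grows from 2 heavy atoms to 4, gains fluorine and loses its one hydrogen-bond acceptor, and these compounds cannot show which of these differences, if any, goes with the step. From the compounds shown here alone, it also remains open whether an amine, a carboxylic acid or a longer carbon chain at this same place would give a number further from those of compound 2 and compound 3, or whether the number would stay in the same narrow band.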